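The source may hold more compounds than are shown below. What is called first, only, known or untested is meant among the compounds shown, and "the series" means these compounds.

Compound 2 `CC#C[C@@H](Cc1nnn[nH]1)c1ccc(OCc2ccc3sc(F)c(-c4ccccc4C)c3c2)cc1` is one of three close relatives measured in an ADME assay on microsomes from liver (Rattus norvegicus) for metabolic stability; on this read-out higher numbers stand for a longer-lived compound and lower numbers for a shorter-lived compound. In this assay compound 2 gives 0.367 h, level at the digits shown with compound 3 `CC#C[C@@H](Cc1nnn[nH]1)c1ccc(OCc2ccc3scc(-c4cc(OCCOC)ccc4C)c3c2)cc1`, which gives 0.367 h; together they stand highest of the three numbers, though all three lie within the scatter of one another, and compound 1 `CC#C[C@@H](Cc1nnn[nH]1)c1ccc(OCc2ccc3sc(F)c(-c4ccc(OCCOC)cc4C)c3c2)cc1` gives 0.35 h. Among the measured compounds shown here, the only measured step that changes a single group, a 1.0-fold higher number from compound 1 to compound 2 (0.02 log units; within the scatter), is within the scatter. Compound 4 `CC#C[C@@H](Cc1nnn[nH]1)c1ccc(OCc2ccc3sc(C)c(-c4ccccc4C)c3c2)cc1` differs from compound 2 by one change: methyl in place of fluoro on an aromatic carbon. For the measured compounds named here, no measured pair shows this same exchange, so nothing bears on it directly; compound 3 carries hydrogen where compound 2 carries fluoro, but it also differs elsewhere, so its value can only be set beside that of compound 2, which it matches. Because a 1.0-fold higher number from compound 1 to compound 2 (0.02 log units; within the scatter) shows one single-group change leaving this assay unmoved, and the three measured values cluster tightly, the expected step for compound 4 is a 1.0-fold higher number from compound 2 to compound 4 (0.00 log units; within the scatter), nothing beyond the scatter. Compound 4 is therefore estimated at 0.37 h, within a range from 0.2 h to 0.7 h.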

Compound 4, half-life: 0.483 h
Compound 4: middle estimate off by 1.3-fold (0.12 log units), on the low side, and the stated range covers the measured number.
By their numbers in this assay, from the lowest: compounds 1, 2, 3 and 4 (each within the scatter of the next).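

Among the compounds shown here, replacing fluoro with methyl on the aromatic carbon next to the ring sulfur gives a 1.3-fold higher number from compound 2 to compound 4 (0.12 log units; within the scatter) in this assay and is the first direct reading of a change at this position. The compounds shown therefore do not separate these two groups, each a single heavy atom with no hydrogen-bond donors or acceptors, beyond the usual scatter of repeated measurements. No measurement here offers an explanation for this result.

As far as these compounds go, whether an amine, a carboxylic acid or a longer chain at this position would shift the half-life beyond the scatter remains open. Hydrogen is also unresolved as a single change here: compound 3 carries it, but that compound also differs from compound 2 elsewhere.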